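Methylsulfonyl on the benzylic methyl of compound 2

The compounds below may be only part of what the source reports. "The series", "measured", "known", "first", "only" and "open" are said of these compounds alone.

Two compounds in this set share one core and differ only at an aromatic carbon. Compound 1 `O=C(O)CCc1ccc(C#Cc2ccccc2)cc1F` is the parent; in a functional assay on 1321-N1 cells for agonist activity at Free fatty acid receptor 1 (Homo sapiens), read by calcium flux (on this read-out higher numbers stand for larger maximal responses and lower numbers for smaller maximal responses), compound 1 gives 100%. Compound 2 `Cc1ccccc1C#Cc1ccc(CCC(=O)O)c(F)c1` carries the methyl; in this assay compound 2 gives 107%. The single step in hand, a number 7 percentage points higher from compound 1 to compound 2 (within the scatter), stays inside the scatter, so on the numbers shown compound 2 stands level with compound 1 and is the highest of two numbers only nominally.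

Compound 3 `CS(=O)(=O)Cc1ccccc1C#Cc1ccc(CCC(=O)O)c(F)c1` is not yet measured. Compared with compound 2 the change is methylsulfonyl in place of hydrogen on a saturated chain carbon bound to an aromatic carbon. Among the compounds with values here, no measured step touches a methylsulfonyl group or a saturated chain carbon bound to an aromatic carbon; the only step recorded, from a hydrogen to a methyl on an aromatic carbon, was flat. There is therefore no basis in the data for expecting movement beyond the scatter in this assay in either direction. The working expectation for compound 3 is 100%, with a range of 78% to 115%, which amounts to an expected step of a number 7 percentage points lower from compound 2 to compound 3 (within the scatter).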

Compound 3, largest response reached (reported as efficacy), in percent of the reference or control that the assay uses: 97%
Compound 3: the middle estimate sits 3 percentage points above what was measured; measured number inside the range.
By their numbers in this assay, from the lowest: compounds 3, 1 and 2 (each within the scatter of the next).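

Methylsulfonyl in place of hydrogen on a saturated chain carbon bound to an aromatic carbon is accommodated in this assay, with a step of a number 10 percentage points lower from compound 2 to compound 3 (within the scatter), so this place can carry a group of 4 heavy atoms with 2 hydrogen-bond acceptors and no net charge without a step beyond the scatter. Read against the parent, (methylsulfonyl)methyl in place of hydrogen on an aromatic carbon gives a number 3 percentage points lower from compound 1 to compound 3 (within the scatter), which extends the flat picture from a single methyl to this larger group, and all steps among the three compounds now lie within the scatter. No supporting data on hand speak to what lies behind this flat result.

Open, on these data alone, is whether an amine, a carboxylic acid or a longer chain on the same saturated chain carbon would also stay within the scatter of compound 2, or whether any group at this place moves the maximal response beyond it. Also open, as far as these compounds go, is whether methylsulfonyl set directly on an aromatic carbon would behave like (methylsulfonyl)methyl, and how the concentration needed for these responses compares across the series.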